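This account rests on a few compounds, and the source may have more. Where it says the series, first, only, none or still open, it means among the compounds named here.

Values so far in a physicochemical assay for lipophilicity; on this read-out lower numbers stand for lower lipophilicity and higher numbers for higher lipophilicity

- Compound 1 `O=S(=O)(Nc1ncccn1)c1ccc2c(c1)OCC[C@@H]2c1ccc(C(F)(F)F)cc1-c1ccc(F)nc1` gives 2.8
- Compound 2 `O=C1OCCN1c1cc(C(F)(F)F)ccc1[C@H]1CCOc2cc(S(=O)(=O)Nc3nccs3)ccc21` gives 2.1

Compound 2 is the lower of the two (2.1), and the gap to compound 1 (2.8) lies beyond the scatter. These two compounds differ in more than one place, so the gap cannot be tied to any single change.

Compound 3 `O=S(=O)(Nc1nccs1)c1ccc2c(c1)OCC[C@@H]2c1ccc(C(F)(F)F)cc1-n1ccnn1` has not yet been measured in this assay. It differs from compound 2 in one place: 1H-1,2,3-triazol-1-yl in place of 2-oxo-1,3-oxazolidin-3-yl on an aromatic carbon, ortho to a large group and meta to a trifluoromethyl group (1H-1,2,3-triazol-1-yl in place of 2-oxo-1,3-oxazolidin-3-yl on an aromatic carbon).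

Among the compounds with values here, no measured pair shows this change, so the expectation has no direct precedent. Starting from compound 2 (2.1), only one five-membered ring group is exchanged, so a large move in this assay is not expected. A small rise, close to the usual scatter, is the expected outcome (a number 0.30 log units higher from compound 2 to compound 3 (within the scatter)). The estimated value for compound 3 is 2.4 with an expected range (1.9 to 2.9).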

Compound 3, distribution coefficient: 2.3
Compound 3: middle estimate off by 0.10 log units, on the high side, and the stated range covers the measured number.
By their numbers in this assay, from the lowest: compounds 2 and 3 (each within the scatter of the next); then compound 1.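

In this assay, the series now has its first single-place step, at the aromatic carbon ortho to a large group and meta to a trifluoromethyl group: a number 0.20 log units higher from compound 2 to compound 3 (within the scatter). At this position, 1H-1,2,3-triazol-1-yl, a five-membered aromatic ring with 3 hetero atoms, therefore stands in for 2-oxo-1,3-oxazolidin-3-yl, a five-membered non-aromatic ring with 2 hetero atoms and a double bond outside aromatic rings, with no shift in the read-out beyond the scatter, at least with the rest of compound 2 held constant. Nothing on hand explains why these two groups give such close numbers.

On these data alone, it remains open whether the read-out would stay within the scatter with a group of a different kind at this position, such as a primary amine, a carboxylic acid or a longer alkyl chain, or whether these two five-membered rings are simply a close pair. Within the data shown here, compound 1 is joined to the others by no single-place step, so how much of its distance from them belongs to this position cannot be read.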